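The source may hold more compounds than are shown below. What is called first, only, known or untested is meant among the compounds shown, and "the series" means these compounds.

Series notes on an ADME assay on Vero cells (Chlorocebus sabaeus) for cytotoxicity, read by MTT assay, with a stated time of 72 h; on this read-out higher numbers stand for weaker inhibition and lower numbers for stronger inhibition. Compound 1 `CN(C)C(=O)C[C@H](CSc1ccccc1)Nc1c(C(=O)N/N=C/c2ccc(F)cc2)cnc2c(C(F)(F)F)cccc12`, compound 2 `CN(C)C(=O)C[C@H](CSc1ccccc1)Nc1c(C(=O)N/N=C/c2cccnc2)cnc2c(C(F)(F)F)cccc12` and compound 3 `CN(C)C(=O)C[C@H](CSc1ccccc1)Nc1c(C(=O)N/N=C/c2ccc(Br)s2)cnc2c(C(F)(F)F)cccc12` share one core and differ only in the group on a carbon with a double bond to nitrogen. In this assay compound 1 gives > 62.5 ug/mL, which is a limit of the assay and not a number. Compound 2 gives > 62.5 ug/mL in this assay, again a limit. Compound 3 gives > 62.5 ug/mL in this assay, also a limit. Compound 3 thus has no number of its own in this assay to place it. The steps a step that the two limits leave unreadable from compound 1 to compound 2, a step that the two limits leave unreadable from compound 1 to compound 3 and a step that the two limits leave unreadable from compound 2 to compound 3 are accordingly unreadable, since (the limit of > 62.5 ug/mL in this assay, at which 3 of the 3 values shown sit).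

Compound 4 `CCCCCCCC/C=N/NC(=O)c1cnc2c(C(F)(F)F)cccc2c1N[C@@H](CSc1ccccc1)CC(=O)N(C)C` follows from compound 3 by octyl in place of 5-bromothiophen-2-yl on a carbon with a double bond to nitrogen. Going by the values given here, no measured step involves an octyl group, and none of the three measured steps has a readable size, so the only bearing they have is that each exchange made so far at this position has left the read-out at the limit. The step from compound 3 to compound 4 is therefore expected to be a step that the limit leaves unreadable from compound 3 to compound 4, meaning no readable change. For compound 4 the estimate in this assay is 70 ug/mL, with a range from 30 ug/mL to 160 ug/mL, and most likely only a limit is reported once more.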

Compound 4, half-maximal inhibitory concentration: > 62.5 ug/mL
Compound 4 ended at the assay's limit (the forecaster's own chance of this, stated with the estimate: 75%); the middle value is on the limit's open side.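

The steps linking compound 4 to compound 1, compound 2 and compound 3 in this assay cannot be read, and no new step follows, because all four compounds rest at one limit and not at a number: the limit of > 62.5 ug/mL in this assay, at which 4 of the 4 values shown sit.

The compounds shown leave open at what concentration any of the four reaches half-maximal inhibition in this assay, and whether the group on this carbon changes that concentration.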